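The compounds below may be only part of what the source reports. "The series", "measured", "known", "first", "only" and "open" are said of these compounds alone.

In a functional assay on NCI-H1299 cells (Homo sapiens) for inhibition, read by CCK-8 assay, with a stated time of 72 h, tested at 1 uM (a lower number here means less inhibition of growth, a higher number more inhibition of growth at the concentration tested), compound 1 `CN(C)C(=O)c1cc2cnc(Nc3ccc(NC(=O)C4(C(=O)Nc5ccc(F)cc5)CC4)cc3)nc2n1C1CCCC1` gives 93.3%, while compound 2 `CN(C)C(=O)c1cc2cnc(Nc3ccc(NC(=O)C4(C(=O)Nc5cccc(F)c5)CC4)cc3)nc2n1C1CCCC1` gives 64.2%. Among the measured compounds shown here, compound 2 therefore holds the lower of the two numbers known so far, and the gap between them is beyond the usual scatter. Compound 3 `CN(C)C(=O)c1cc2cnc(Nc3ccc(NC(=O)C4(C(=O)Nc5ccccc5F)CC4)cc3)nc2n1C1CCCC1` is a close relative of compound 2, with one change: 2-fluorophenyl in place of 3-fluorophenyl on an amide-type nitrogen. In words, 2-fluorophenyl stands in place of 3-fluorophenyl on an amide-type nitrogen, so the two compounds have the same atoms, joined differently.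

For the measured compounds named here, only one measured step bears on this change: a number 29.1 percentage points lower from compound 1 to compound 2 (beyond the scatter), which comes with 3-fluorophenyl in place of 4-fluorophenyl at that same place. This modest step shows that the location of the fluorine on the phenyl ring can matter in this pair. However, no measured compound carries 2-fluorophenyl, so the step does not settle a direction for compound 3. The expected step is a number 5.8 percentage points higher from compound 2 to compound 3 (within the scatter), an estimate held with little confidence in its direction. For compound 3, the estimated value is 70%, with an expected range from 45% to 90%.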

Compound 3, percent growth inhibition at one concentration: 70.2%
The estimate for compound 3 lay 0.2 percentage points below the measured number; the measured number falls inside the stated range.
By their numbers in this assay, from the lowest: compounds 2 and 3 (each within the scatter of the next); then compound 1.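

In this assay, 2-fluorophenyl in place of 3-fluorophenyl on the amide-type nitrogen gives a number 6 percentage points higher from compound 2 to compound 3 (within the scatter), so these two arrangements cannot be told apart, even though compound 1 had already shown that the place of the fluorine can matter. The comparison with 4-fluorophenyl gives a number 23.1 percentage points lower from compound 1 to compound 3 (beyond the scatter), which means that compound 1 now stands above both of its relatives by more than the scatter, and its high number no longer rests on a single comparison: among these three compounds, only the 4-fluorophenyl group gives the high growth inhibition at the concentration tested, and no compound here goes against that. Nothing available explains why the 4-fluorophenyl compound stands apart from the other two.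

The three compounds differ only in where one fluorine sits, so they leave open whether the fluorine itself is needed at all, a question that plain phenyl at this place would address. They also leave open whether another group in the same place, such as 4-chlorophenyl or 4-methoxyphenyl, would hold the high number seen for compound 1.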